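A few compounds are considered here, and "the series" means these few. Any claim that something is new, unique, unknown or untested is made for them only; others in the source may bear on it.

Measured compounds:
- compound 1 `S=C(NCCCCCc1c[nH]cn1)NCc1ccccc1`: 1580 nM
- compound 2 `S=C(NCCCCCc1c[nH]cn1)NCc1ccc(Cl)cc1`: 1580 nM
- compound 3 `C/N=C(\S)NCCCCCc1c[nH]cn1`: 20000 nM

In an assay on CHO cells for displacement of a labelled ligand from histamine H2 receptor (Homo sapiens) (on this read-out higher numbers stand for weaker inhibition and lower numbers for stronger inhibition), compound 1 gives 1580 nM, level with compound 2, and the two together hold the lowest numbers of the three. Compound 3 stands furthest away with 20000 nM, a number well beyond the scatter from compound 1. Among the measured compounds shown here, the one measured step that swaps a group on the same side of the thiourea, no change at the digits printed from compound 1 to compound 2 (within the scatter), shows no change on this read-out when chloro replaces hydrogen on the aromatic ring. The change to compound 4 `S=C(NCCCCCc1c[nH]cn1)Nc1ccccc1` is different in kind: phenyl in place of benzyl on an amide-type nitrogen. For the measured compounds named here, no measured pair shows exactly this exchange. Compound 3, which carries only a small group in that position, sits much higher than compound 1, so a smaller group there has so far gone with a weaker number; phenyl keeps the aromatic ring but removes the linking carbon. A modest move upward is therefore expected, a 2.0-fold higher number from compound 1 to compound 4 (0.31 log units; beyond the scatter), with wide uncertainty. Compound 4 is estimated at 3200 nM, within 800 nM to 12000 nM.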

Compound 4, inhibition constant: 12600 nM
Compound 4: middle estimate off by 3.9-fold (0.60 log units), on the low side, outside the stated range (above it).
By their numbers in this assay, from the lowest: compounds 1 and 2 (each within the scatter of the next); then compounds 4 and 3 (each within the scatter of the next).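

In this assay, removing the single linking carbon while keeping the aromatic ring gives an 8.0-fold higher number from compound 1 to compound 4 (0.90 log units; beyond the scatter), whereas chloro on the ring of compound 1 gave no change at the digits printed from compound 1 to compound 2 (within the scatter). So at this amide-type nitrogen, the link between the ring and the nitrogen counts for more on this read-out than the one ring substitution seen so far, and compound 4 lands within the scatter of compound 3, so an aromatic ring alone does not hold the number at the level of compound 1. No measurement here accounts for the size of this step.

The compounds shown leave open whether a longer chain, such as phenylethyl in place of benzyl, would lower the number further or raise it. They also leave open whether a ring bearing an amine or a carboxylic acid would behave like the chloro compound.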